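The compounds below may be only part of what the source reports. "The series", "measured", "known", "first", "only" and "open" are said of these compounds alone.

Compounds measured in a functional assay on the whole organism for inhibition, with Rattus norvegicus as the target, read by paw edema, with stated times of 1 h and 3 h, at a dose of 50 mg/kg by the oral route (a lower number here means less inhibition, a higher number more inhibition at the dose given (going by the name of the read-out)), so far:
compound 1, `C/C(=N\OCC(=O)O)c1ccc(O)cc1`
compound 2, `COc1ccc(/C(C)=N/OCC(=O)O)cc1`
compound 3, `C/C(=N\OCC(=O)O)c1ccc(S(C)(=O)=O)cc1`

In this assay compound 1 gives < 20%, which is a limit of the assay and not a number. Compound 2 likewise gives < 20%, again a limit rather than a number. Within the data shown here, compound 3 gives 20%; it stands as the only number in the set. The step of a number no lower from compound 1 to compound 3 (the limit leaves the size open) and the step of a number no lower from compound 2 to compound 3 (the limit leaves the size open) therefore carry no readable size, and a step that the two limits leave unreadable from compound 1 to compound 2 is left unreadable by both limits; the limit of < 20% in this assay, at which 2 of the 3 values shown sit, is where two of the three values sit.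

Compound 4, `CC(=O)Nc1ccc(/C(C)=N/OCC(=O)O)cc1`, differs from compound 3 in one place: acetamido in place of methylsulfonyl on an aromatic carbon. Among the measured compounds shown here, the steps that bear on this change are the two leading into compound 3, and neither gives a size; each change so far at that aromatic carbon has left the read-out at or close to the limit. No step beyond the scatter is therefore expected for a number 2 percentage points lower from compound 3 to compound 4 (within the scatter). Compound 4 is estimated at 18%, with a range from 5% to 35%.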

Compound 4, a percentage reported as inhibition, in the whole organism at one dose (the size of the read-out at that dose, not a potency): < 20%
Compound 4: only a limit was reported; the forecaster's own chance of this, stated with the estimate: 50%; the middle value is on the limit's open side.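

In this assay compound 4 gives < 20%, which is a limit of the assay and not a number. Among these compounds, the change of methylsulfonyl to acetamido gives a number no higher from compound 3 to compound 4 (the limit leaves the size open), so a third group at this aromatic carbon, here an amide with a hydrogen-bond donor, yields no number and compound 3 stays the only compound with one. The steps among compound 1, compound 2 and compound 4 cannot be read, and the series now gathers at a single place: the limit of < 20% in this assay, at which 3 of the 4 values shown sit.

On these data alone, whether any group at this aromatic carbon can carry the read-out clear of the limit stays open; an amine, a carboxylic acid or a longer chain there would bear on this. Also open, as far as these compounds go, is how far the compounds at the limit lie from one another, and whether a change elsewhere on the shared core would count for more.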